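A few compounds are considered here, and "the series" means these few. Any claim that something is new, unique, unknown or untested is made for them only; others in the source may bear on it.

Measured so far in a functional assay on HCT-116 cells (Homo sapiens) for cytotoxicity, read by MTT assay, with a stated time of 72 h; a lower number here means a stronger inhibitor, a higher number a weaker inhibitor:
compound 1 `COc1ncc(-c2ccc3nc(NC(=O)N4CCCC4)nn3c2)cc1NS(=O)(=O)c1ccc(F)cc1`: 1290 nM
compound 2 `COc1ncc(-c2ccc3nc(NC(=O)NCC(=O)N4CCCC4)nn3c2)cc1NS(=O)(=O)c1ccc(F)cc1`: 140 nM
compound 3 `CCN(CC)CCNC(=O)Nc1nc2ccc(-c3cnc(OC)c(NS(=O)(=O)c4ccc(F)cc4F)c3)cn2n1`: 140 nM

Compound 1 gives the highest number of the three, with compound 2 and compound 3 both lying beyond the scatter below it. Compound 4 `COc1ncc(-c2ccc3nc(NC(=O)NCCN4CCN(C)CC4)nn3c2)cc1NS(=O)(=O)c1ccc(F)cc1` has not been measured. It differs from compound 1 in one place: (2-(4-methylpiperazin-1-yl)ethyl)amino in place of pyrrolidin-1-yl on a carbonyl carbon One measured step bears on this change, a 9.2-fold lower number from compound 1 to compound 2 (0.96 log units; beyond the scatter), where the same carbonyl carbon was altered. Compound 3, which carries a different chain on that carbon but also differs from compound 1 elsewhere, shows a number matching that of compound 2. A step of about a 6.5-fold lower number from compound 1 to compound 4 (0.81 log units; beyond the scatter) is therefore expected, toward a lower number. The estimate for compound 4 in this assay is 200 nM, within a range from 60 nM to 650 nM.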

Compound 4, half-maximal inhibitory concentration: 260 nM
For compound 4 the middle estimate is 1.3-fold (0.11 log units) below the measured one; the measured number falls inside the stated range.
By their numbers in this assay, from the lowest: compounds 2, 3 and 4 (each within the scatter of the next); then compound 1.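

In this assay the (2-(4-methylpiperazin-1-yl)ethyl)amino group in place of pyrrolidin-1-yl on the carbonyl carbon gives a 5.0-fold lower number from compound 1 to compound 4 (0.70 log units; beyond the scatter) and so shows, without any other change to the core, that a second chain here also lowers the number. The comparison of the two chains, (4-methylpiperazin-1-yl)methyl in place of (pyrrolidin-1-yl)carbonyl, gives a 1.9-fold higher number from compound 2 to compound 4 (0.27 log units; within the scatter) and does not separate them. No measurement at hand explains either step.

As far as these compounds go, whether the terminal ring matters remains open, since a plain ethylamino group or a carboxylic acid at the chain end would be needed to tell. From the compounds shown here alone, a longer chain also remains untested in these compounds.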